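Amide replacing urea on the diaryl pyrazole series

The source may hold more compounds than are shown below. What is called first, only, known or untested is meant among the compounds shown, and "the series" means these compounds.

Measured so far in a functional assay on KM12 cells (Homo sapiens) for inhibition, read by sulforhodamine B assay, with a stated time of 48 h; a lower number here means that less compound is tolerated, a higher number that more compound is tolerated:
compound 1 `COc1cc(-c2nn(-c3cccc(NC(=O)Nc4cc(C(F)(F)F)cc(C(F)(F)F)c4)c3)cc2-c2ccncc2)ccc1Cl` gives 3390 nM
compound 2 `COc1cc(-c2nn(-c3cccc(NC(=O)c4cccc(C(F)(F)F)c4)c3)cc2-c2ccncc2)ccc1Cl` gives a limit, > 50000 nM
compound 3 `O=C(Nc1cccc(-n2cc(-c3ccncc3)c(-c3ccc(Cl)c(O)c3)n2)c1)Nc1cc(C(F)(F)F)cc(C(F)(F)F)c1` gives 4060 nM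

Within the data shown here, compound 1 and compound 3 share the urea linker and the bis(trifluoromethyl)phenyl group, and the one change between them, a 1.2-fold higher number from compound 1 to compound 3 (0.08 log units; within the scatter), is the only measured step. Compound 2 carries an amide instead of the urea, and in this assay it stands only at a limit of the assay, the one described by the limit of > 50000 nM in this assay, at which 1 of the 3 values shown sits; no number is known for it.

Compound 4 `COc1cc(-c2nn(-c3cccc(NC(=O)c4ccccc4)c3)cc2-c2ccncc2)ccc1Cl` keeps the amide of compound 2 and differs from it by hydrogen in place of trifluoromethyl on an aromatic carbon. Among the measured compounds shown here, no measured step touches the amide side of the molecule, so the step from compound 1 to compound 3 does not bear on this change. Given that compound 2 itself sits at a limit, the expected step is a step that the limit leaves unreadable from compound 2 to compound 4, with no direction that the numbers support. Compound 4 is expected to give 60000 nM, within 20000 nM to 200000 nM, most likely again reported only as a limit.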

Compound 4, concentration lethal to 50% of the cells: > 100000 nM
Compound 4: only a limit was reported; the forecaster's own chance of this, stated with the estimate: 75%; middle value at least 1.6-fold (0.22 log units) from the limit.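

Compound 2 and compound 4 both stand only as limits of the assay in this assay, and the step between them cannot be read. The compounds shown leave open what number either amide would give, and whether hydrogen in place of trifluoromethyl changes the read-out at all.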